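From vinyl to ethynyl on the bromo compound

The compounds below may be only part of what the source reports. "The series", "measured", "known", "first", "only" and "open" are said of these compounds alone.

Measured so far in a functional assay on NCI-H522 cells (Homo sapiens) for cytotoxicity, with a stated time of 3 days; on this read-out lower numbers stand for stronger inhibition and higher numbers for weaker inhibition:
- compound 1 (`C=Cc1csc(Br)n1`) gives > 40000 nM as a limit
- compound 2 (`C#Cc1nc(-c2ccccc2)cs1`) gives 5650 nM as a number

Compound 1 stands at the limit of > 40000 nM in this assay, at which 1 of the 2 values shown sits, and so has a limit and no number of its own. Compound 3 (`C#Cc1csc(Br)n1`) departs from compound 1 in one place (ethynyl in place of vinyl on an aromatic carbon) with ethynyl in place of vinyl on an aromatic carbon, next to the ring nitrogen. Going by the values given here, no measured pair gives the size of this change. Compound 2 also carries ethynyl and reads as a number (5650 nM), but its structure differs from that of compound 3 elsewhere. On that single comparison, a move toward stronger inhibition in this assay is expected, and compound 3 may still end at the limit. The expected size is an at least 3.3-fold lower number from compound 1 to compound 3 (0.52 log units; beyond the scatter) and it is counted from a limit. For compound 3 the estimate is 12000 nM (expected range 2500 nM to 40000 nM).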

Compound 3, half-maximal inhibitory concentration: > 40000 nM
Compound 3: only a limit was reported (the forecaster's own chance of this, stated with the estimate: 35%); middle value at least 3.3-fold (0.52 log units) from the limit.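

Compound 1 and compound 3 both stand at a limit in this assay, so the ethynyl for vinyl change gives no readable step between them: the limit of > 40000 nM in this assay, at which 2 of the 3 values shown sit. The compounds shown leave open whether ethynyl in place of vinyl on an aromatic carbon changes the read-out at all, and by how much.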